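The source may hold more compounds than are shown below. What is called first, only, known or untested is meant among the compounds shown, and "the series" means these compounds.

Measured so far in an assay for inhibition of Fatty-acid amide hydrolase 1 (Rattus norvegicus); a lower number here means a stronger inhibitor, a higher number a weaker inhibitor:
compound 1, `CCOC(=O)c1cccc(-c2cnc(C(=O)CCc3ccc(-c4ccccc4)cc3)o2)n1` — 3 nM
compound 2, `COC(=O)c1cc(-c2cnc(C(=O)CCc3ccc(-c4ccccc4)cc3)o2)ccn1` — 1.5 nM
compound 3, `COC(=O)c1cnc(C(=O)CCc2ccc(Oc3ccccc3)cc2)o1` — 1.7 nM

Compound 2 holds the lowest of the three numbers, yet compound 3 sits within the scatter of it and so does compound 1, so the three read as one level rather than an order. Going by the values given here, no pair among them differs in one place only, so no single step has been measured in this assay.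

Compound 4, `N#Cc1cccc(-c2cnc(C(=O)CCc3ccc(-c4ccccc4)cc3)o2)n1`, is the next to be run in this assay. The change from compound 2: 6-cyanopyridin-2-yl in place of 2-(methoxycarbonyl)pyridin-4-yl on an aromatic carbon. The rest of compound 2 is kept unchanged. Compound 1 carries a differently substituted pyridinyl group on the shared core and gives 3 nM, within the scatter of compound 2. On that basis the step to compound 4 is expected to be small, a modest rise at most, a 2.0-fold higher number from compound 2 to compound 4 (0.30 log units; within the scatter). Compound 4 is estimated at 3 nM, with a range from 1 nM to 9 nM.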

Compound 4, inhibition constant: 2.9 nM
Beside the measured number, compound 4's estimate is 1.0-fold (0.01 log units) above it; the range from low to high includes it.
By their numbers in this assay, from the lowest: compounds 2, 3, 4 and 1 (each within the scatter of the next).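

Going by these compounds alone, the first step in one place only, a 1.0-fold lower number from compound 1 to compound 4 (0.01 log units; within the scatter), shows that cyano can stand in place of ethoxycarbonyl on the pyridinyl group with no change beyond the scatter in this assay. The wider exchange, a 1.9-fold higher number from compound 2 to compound 4 (0.29 log units; within the scatter), replaces the whole 2-(methoxycarbonyl)pyridin-4-yl group with 6-cyanopyridin-2-yl and also stays within the scatter, so at this place on the shared core, neither step separates the compounds. Nothing given here accounts for the size of either step.

On these data alone, all the steps read so far lie within the scatter, so it remains open whether any substituent on this pyridinyl group moves the number beyond it. A carboxylic acid or a primary amide in place of the cyano group would test this, and steps involving compound 3 cannot be read, leaving its differences from the other compounds unresolved.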